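Ortho halogen swap on the benzyl arm of compound 3

The source may hold more compounds than are shown below. What is called first, only, known or untested is meant among the compounds shown, and "the series" means these compounds.

Measured so far:
compound 1 `COc1cccc(Cc2cnc(CCc3ccc(-c4ccccc4C(=O)O)cc3)[nH]2)c1` gives 4120 nM in an in vitro functional assay on cells for agonist activity at Bombesin receptor subtype-3 (Homo sapiens), read by luminescence and calcium flux; a higher number here means that more compound is needed for the effect, a lower number that less compound is needed
compound 2 `COc1ccc(Cc2cnc(CCc3ccc(-c4ccccc4C(=O)O)cc3)[nH]2)cc1` gives 5360 nM in this assay
compound 3 `O=C(O)c1ccccc1-c1ccc(CCc2ncc(Cc3ccccc3F)[nH]2)cc1` gives 177 nM in this assay

Compound 3 stands lowest of the three numbers in this assay; nearest is compound 1 by the step of a 23-fold lower number from compound 1 to compound 3 (1.37 log units; beyond the scatter), furthest compound 2 by the step of a 30-fold lower number from compound 2 to compound 3 (1.48 log units; beyond the scatter). The step of a 1.3-fold higher number from compound 1 to compound 2 (0.11 log units; within the scatter) lies within the scatter. Compound 4 `O=C(O)c1ccccc1-c1ccc(CCc2ncc(Cc3ccccc3Cl)[nH]2)cc1` differs from compound 3 by chloro in place of fluoro on an aromatic carbon. Within the data shown here, no measured step exchanges one halogen for another; the measured steps shift or replace a methoxy on the benzyl ring, so none bears directly on this change. A step beyond the scatter in this assay is therefore not expected; the step from compound 3 to compound 4 is estimated at a 1.1-fold lower number from compound 3 to compound 4 (0.04 log units; within the scatter). Compound 4 is estimated at 160 nM, expected between 50 nM and 500 nM.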

Compound 4, half-maximal effective concentration: 292 nM
Compound 4: middle estimate off by 1.8-fold (0.26 log units), on the low side, within the range that was stated.
By their numbers in this assay, from the lowest: compounds 3 and 4 (each within the scatter of the next); then compounds 1 and 2 (each within the scatter of the next).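

In this assay, chloro in place of fluoro on the benzyl ring leaves the number within the scatter (a 1.6-fold higher number from compound 3 to compound 4 (0.22 log units; within the scatter)), so compound 3 and compound 4 cannot be separated here. The large distance from the methoxy compounds is therefore not confined to fluoro, and it holds for chloro on both sides (an 18-fold lower number from compound 2 to compound 4 (1.26 log units; beyond the scatter); a 14-fold lower number from compound 1 to compound 4 (1.15 log units; beyond the scatter)). No available evidence accounts for these steps. Open, on these data alone, is whether bromo, methyl or trifluoromethyl at this place matches the two halogens. Also open, as far as these compounds go, is how 3-chlorophenyl, 4-chlorophenyl or unsubstituted phenyl compares.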